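The source may report more compounds than this note shows. Statements on the series, on what has been measured and on what is new or still open speak of the compounds shown alone.

Of the compounds shown here, three from this series have been tested in a functional assay on SMMC-7721 cells (Homo sapiens) for cytotoxicity, read by MTT assay, with a stated time of 4 days; on this read-out lower numbers stand for stronger inhibition and higher numbers for weaker inhibition. Compound 1, `C=C1C[C@]23C[C@@]1(O)CC[C@@H]2c1cccc(C)c1[C@@H]3Cn1cc(-c2ccc(C)cc2)nn1`, gives > 20000 nM in this assay, which is a limit of the measurement rather than a number. Compound 2, `Cc1c(O)ccc2c1[C@H](Cn1cc(-c3ccccc3)nn1)[C@@]13CC(=O)[C@@](C)(CC[C@@H]21)C3`, likewise gives > 20000 nM in this assay, again a limit. Compound 3, `C=C1C[C@]23C[C@@]1(O)CC[C@H]2c1ccc(OS(=O)(=O)c2ccc(C)cc2)c(C)c1[C@@H]3Cn1cc(-c2ccccc2)nn1`, also reaches only a limit, > 20000 nM. Compound 2 therefore stands exactly where every other value shown stands: the limit of > 20000 nM in this assay, at which 3 of the 3 values shown sit. For the measured compounds named here, no compound has yet given a number within the range of the assay, so no measured step shows how any structural change alters the outcome.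

Compound 4, `Cc1c(O)ccc2c1[C@H](Cn1cc(-c3ccc(C(F)(F)F)cc3)nn1)[C@@]13CC(=O)[C@@](C)(CC[C@@H]21)C3`, is the next compound to be tested. It differs from compound 2 by trifluoromethyl in place of hydrogen on an aromatic carbon. With all three measured compounds sitting at the limit, there is no ground for expecting a shift in either direction. The step expected from compound 2 to compound 4 is a step that the limit leaves unreadable from compound 2 to compound 4, that is, none beyond the scatter. Compound 4 is accordingly expected to give about 25000 nM in this assay, somewhere between 8000 nM and 80000 nM, with a strong chance that only a limit is reported once more.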

Compound 4, half-maximal inhibitory concentration: > 20000 nM
Compound 4: a limit, no number; the forecaster's own chance of this, stated with the estimate: 80%; the middle value is on the limit's open side.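

In this assay compound 4 gives > 20000 nM which is a limit and not a number. Compound 2 also sits at a limit, so no step can be read between compound 2 and compound 4. The compounds shown leave open which structural change, if any, would give an actual number rather than a limit.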